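Replacing piperidin-1-yl with propylamino on a thiocarbonyl carbon

This account rests on a few compounds, and the source may have more. Where it says the series, first, only, none or still open, it means among the compounds named here.

compound 1 `Oc1ccc(C2C/C(=N\NC(=S)N3CCCC3)c3ccc(O)cc3O2)cc1` gives 51700 nM
compound 2 `Oc1ccc(C2C/C(=N\NC(=S)N3CCCCC3)c3ccc(O)cc3O2)cc1` gives 55300 nM

Within the data shown here, in a functional assay on DU-145 cells (Homo sapiens) for cytotoxicity, read by MTT assay, with a stated time of 72 h (on this read-out lower numbers stand for stronger inhibition and higher numbers for weaker inhibition), compound 2 gives 55300 nM, within the scatter of compound 1, the only other compound measured. Compound 3 `CCCNC(=S)N/N=C1\CC(c2ccc(O)cc2)Oc2cc(O)ccc21` differs from compound 2 at one place: propylamino in place of piperidin-1-yl on a thiocarbonyl carbon. Among the measured compounds shown here, the one measured step that bears on this is a 1.1-fold higher number from compound 1 to compound 2 (0.03 log units; within the scatter), which exchanges pyrrolidin-1-yl and piperidin-1-yl at that same place. For the measured compounds named here, no measured step covers an open chain, so this guide is weak. The estimated step is a 1.2-fold lower number from compound 2 to compound 3 (0.09 log units; within the scatter), and no change beyond the scatter is expected. Compound 3 is expected at 45000 nM, within a range of 18000 nM to 100000 nM.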

Compound 3, half-maximal inhibitory concentration: 74700 nM
Beside the measured number, compound 3's estimate is 1.7-fold (0.22 log units) below it; low and high end bracket the measured number.
By their numbers in this assay, from the lowest: compounds 1, 2 and 3 (each within the scatter of the next).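

Putting propylamino on the thiocarbonyl carbon in place of either ring gives a 1.4-fold higher number from compound 2 to compound 3 (0.13 log units; within the scatter) and a 1.4-fold higher number from compound 1 to compound 3 (0.16 log units; within the scatter) in this assay. This position has now held an open chain as well as two rings, and the swap, which also adds a hydrogen-bond donor, moves the number by no more than the scatter. Nothing measured here offers an explanation for how closely these numbers agree. Still open, going by these compounds, is whether a much longer chain, or a chain ending in an amine or a carboxylic acid, would shift the number beyond the scatter.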